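Aryl swap at the amide-type nitrogen of compound 3

The source may hold more compounds than are shown below. What is called first, only, known or untested is meant among the compounds shown, and "the series" means these compounds.

Three members of the series have been measured in a functional assay on MDA-MB-231 cells (Homo sapiens) for antiproliferative activity, read by MTT assay, with a stated time of 72 h; a lower number here means a stronger inhibitor, a higher number a weaker inhibitor. Compound 1 `COc1cc(-c2noc(-c3cccc(NS(=O)(=O)c4ccc(NC(C)=O)cc4)c3)n2)ccc1NC(=O)c1cccnc1` gives only a limit, > 10000 nM. Compound 2 `O=C(Nc1ccc(S(=O)(=O)Nc2cccc(-c3nc(-c4ccc(NC(=O)c5cccnc5)cc4Cl)no3)c2)cc1)NC1CCCC1` likewise returns a limit, > 10000 nM. Compound 3 `NS(=O)(=O)c1ccc(NC(=O)Nc2cccc(-c3nc(-c4ccc(NC(=O)c5cccnc5)cc4Cl)no3)c2)cc1` also sits at a limit, > 10000 nM. No pair among these three differs in one place, so no measured step is available; the whole of what the series shows is the limit of > 10000 nM in this assay, at which 3 of the 3 values shown sit. Compound 3 thus stands where every measured member stands, at the limit, with no number to rank it against compound 1 or compound 2.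

Compound 4 `CC(=O)Nc1ccc(NC(=O)Nc2cccc(-c3nc(-c4ccc(NC(=O)c5cccnc5)cc4Cl)no3)c2)cc1Cl` is the next member and differs from compound 3 in one place: 4-acetamido-3-chlorophenyl in place of 4-sulfamoylphenyl on an amide-type nitrogen. Within the data shown here, with all three measured values at the limit, there is no step from which to read a direction for this change, and nothing shows that the 4-sulfamoylphenyl group or the 4-acetamido-3-chlorophenyl group decides potency. In this assay the step that the estimate means, a number no higher from compound 3 to compound 4 (the limit leaves the size open), is expected to be none beyond the scatter. Compound 4 is expected to give 10000 nM in this assay, within 3000 nM to 30000 nM, most probably again reported as a limit rather than a number.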

Compound 4, half-maximal inhibitory concentration: > 10000 nM
Compound 4 gave a limit, no number; the forecaster's own chance of this, stated with the estimate: 75%; the middle value lies on the limit itself.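

The step from compound 3 to compound 4 cannot be read, as both results are limits and not numbers: the limit of > 10000 nM in this assay, at which 4 of the 4 values shown sit.

The compounds shown leave open whether 4-acetamido-3-chlorophenyl in place of 4-sulfamoylphenyl, or any other difference among them, changes antiproliferative potency; none of them yet has a number to rank.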